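Dropping a methyl from the sulfonamide aryl ring

The compounds below may be only part of what the source reports. "The series", "measured", "known", "first", "only" and "open" are said of these compounds alone.

Measured so far:
Compound 1, `Cc1ccc(S(=O)(=O)N[C@H]2CCN(CCCOc3ccc(C(=O)C4CC4)cc3)C2)cc1`: 380 nM
Compound 2, `O=C(N[C@H]1CCN(CCCOc2ccc(C(=O)C3CC3)cc2)C1)c1csc(-c2cccnc2)n1`: 4000 nM

Both compounds were tested in an assay on isolated protein for binding affinity to histamine H2 receptor (Homo sapiens); on this read-out lower numbers stand for stronger inhibition and higher numbers for weaker inhibition. Of the two numbers, compound 1 gives the lower one with 380 nM, and compound 2 with 4000 nM lies well beyond the usual scatter of it, so compound 1 stands as the tighter binder of the pair. These two compounds differ in more than one place, so no single structural cause can be read from their gap.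

Compound 3, `O=C(c1ccc(OCCCN2CC[C@H](NS(=O)(=O)c3ccccc3)C2)cc1)C1CC1`, has not been measured yet. It is derived from compound 1 by a single small change: hydrogen in place of methyl on an aromatic carbon. Put another way, the (4-methylphenyl)sulfonyl group becomes a phenylsulfonyl group, and nothing else moves.

Among the compounds with values here, no measured pair here shows what such a change does. Since the group that leaves is small and the rest of the molecule is untouched, the expectation is that the step of a 1.3-fold higher number from compound 1 to compound 3 (0.12 log units; within the scatter) stays within the scatter, with perhaps a slight drift toward weaker binding. The value of compound 3 is therefore estimated at 500 nM, in the range from 200 nM to 1300 nM.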

Compound 3, inhibition constant: 1200 nM
For compound 3 the middle estimate is 2.4-fold (0.38 log units) below the measured one, within the range that was stated.
By their numbers in this assay, from the lowest: compound 1; then compound 3; then compound 2.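

Within this assay the methyl turns out to matter: replacing it with hydrogen gives a 3.2-fold higher number from compound 1 to compound 3 (0.50 log units; beyond the scatter) and so moves the number past the usual scatter, toward weaker binding. Within the data shown here, this is the first comparison that differs in one place only, so the shift can be tied to this single change, which removes just one carbon from the 4-methylphenyl group, para to a large group. No accompanying measurement bears on why the loss occurs, so the result describes the size of the effect and gives no explanation for it.

On these data alone, a single step says little about what this position can accept, so it remains open whether an ethyl group, a methoxy group or a chlorine atom in the same place would match the methyl, improve on it or do worse. As far as these compounds go, it also remains open whether removing the methyl would cost a similar amount if another part of the molecule were different, since this one pair shows the change against the core of compound 1 alone.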